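Swapping 5-chloro-2-hydroxyphenyl for 2-aminophenyl in compound 3

The source may report more compounds than this note shows. Statements on the series, on what has been measured and on what is new or still open speak of the compounds shown alone.

Measured so far in a functional assay on G-361 cells (Homo sapiens) for inhibition, with a stated time of 72 h (on this read-out higher numbers stand for weaker inhibition and lower numbers for stronger inhibition), are these compounds:
- compound 1 `NC1CCC(Nc2nc(NCc3ccc(-n4cccn4)cc3)c3ncn(C4CCCC4)c3n2)CC1` with 220 nM
- compound 2 `NC1CCC(Nc2nc(NCc3cc(Cl)ccc3O)c3ncn(C4CCCC4)c3n2)CC1` with 390 nM

Going by the values given here, only two numbers are available in this assay so far, and compound 2 at 390 nM cannot be separated from compound 1 at 220 nM on them. The next compound is compound 3 `Nc1ccccc1CNc1nc(NC2CCC(N)CC2)nc2c1ncn2C1CCCC1`, which differs from compound 2 by one exchange 2-aminophenyl in place of 5-chloro-2-hydroxyphenyl on a saturated chain carbon bound to a nitrogen on an aromatic ring that puts 2-aminophenyl in place of 5-chloro-2-hydroxyphenyl on a saturated chain carbon bound to a nitrogen on an aromatic ring.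

Among the compounds with values here, one measured step bears on this, since it changed the group at that same place. That step, a 1.8-fold higher number from compound 1 to compound 2 (0.25 log units; within the scatter), stayed small even though the two groups differ considerably. It is a single step, and neither of its compounds carries 2-aminophenyl, so the guide is thin.

No shift beyond the scatter is therefore expected, and the estimated step is a 1.0-fold higher number from compound 2 to compound 3 (0.01 log units; within the scatter) in this read-out. For compound 3 the expected value is 400 nM within an estimated range of 130 nM to 1200 nM in this assay when it is measured.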

Compound 3, half-maximal inhibitory concentration: 2070 nM
Beside the measured number, compound 3's estimate is 5.2-fold (0.71 log units) below it, outside the stated range (above it).
By their numbers in this assay, from the lowest: compounds 1 and 2 (each within the scatter of the next); then compound 3.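

In this assay, going by these compounds alone, this position on a saturated chain carbon bound to a nitrogen on an aromatic ring turns out not to be indifferent to the group it carries, which the single earlier step within the scatter could not show. Putting 2-aminophenyl in place of 5-chloro-2-hydroxyphenyl gives a 5.3-fold higher number from compound 2 to compound 3 (0.72 log units; beyond the scatter), and putting it in place of 4-(1H-pyrazol-1-yl)phenyl gives a 9.4-fold higher number from compound 1 to compound 3 (0.97 log units; beyond the scatter), so both steps to the new group lie beyond the scatter, although 5-chloro-2-hydroxyphenyl and 2-aminophenyl have the same counts of hydrogen-bond donors and acceptors and no net charge. Nothing available here gives a cause for this rise.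

The compounds shown leave open which part of the exchange carries the step, since the chlorine leaves and the hydroxy group gives way to the amine in a single change; a 5-chloro-2-aminophenyl or a plain 2-hydroxyphenyl group would separate the two. They also leave open whether the amine itself matters, which a plain phenyl group at this place would test.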